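Cytotoxicity notes: bromo to trifluoromethyl, compound 2 to compound 3

The source may report more compounds than this note shows. Statements on the series, on what has been measured and on what is new or still open speak of the compounds shown alone.

Compound 1 `N#CCCN(Cc1cccs1)S(=O)(=O)c1ccccc1F` gives > 205000 nM as a limit
Compound 2 `N#CCCN(Cc1cccs1)S(=O)(=O)c1ccc(Br)cc1` gives > 173000 nM as a limit

For the measured compounds named here, compound 2 stands only at a limit in an ADME assay on MDCK cells (Canis lupus familiaris) for cytotoxicity, read by MTT assay, with a stated time of 24 h (on this read-out lower numbers stand for higher toxicity in this test and higher numbers for lower toxicity in this test), with > 173000 nM as its entry, and the one other value at hand is a limit too. Compound 3 `N#CCCN(Cc1cccs1)S(=O)(=O)c1ccc(C(F)(F)F)cc1` is not yet measured and follows from compound 2 through trifluoromethyl in place of bromo on an aromatic carbon as its change: trifluoromethyl in place of bromo on an aromatic carbon, para to a large group. Going by the values given here, the only measured step is a step that the two limits leave unreadable from compound 1 to compound 2 and it offers no size to carry forward, so no change beyond the scatter is expected in this assay and no direction can be named. Compound 3 is expected to stay in the same high range, quite possibly reported as a limit again. The expected move is a step that the limit leaves unreadable from compound 2 to compound 3 and it should be read as an estimate only. For compound 3 the estimated value is 175000 nM with an expected range from 90000 nM to 260000 nM in this read-out.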

Compound 3, half-maximal cytotoxic concentration: > 178000 nM
Compound 3 was reported as a limit; the forecaster's own chance of this, stated with the estimate: 80%; middle value at least 1.0-fold (0.00 log units) from the limit.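

In this assay compound 3 gives > 178000 nM as a limit. Compound 2 gives > 173000 nM as a limit too, so the step between compound 2 and compound 3 cannot be read. The compounds shown leave open where the actual half-maximal cytotoxic concentration of each lies, and whether trifluoromethyl and bromo differ on this read-out.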